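The source may hold more compounds than are shown below. What is called first, only, known or untested is meant among the compounds shown, and "the series" means these compounds.

Compound 1 `COc1cc2c(cc1OC)C(CC(=O)NC(C)C)CC2` and compound 2 `COc1cc2c(cc1OC)C(CC(=O)NCc1ccccc1)CC2` share one core and differ only in the group on the amide-type nitrogen. In a functional assay on the whole organism (strain Wistar) for inhibition, with Rattus norvegicus as the target, read by paw edema, with stated times of 60 min and 2 h, at a dose of 100 mg/kg by the oral route (a lower number here means less inhibition, a higher number more inhibition at the dose given (going by the name of the read-out)), compound 1 gives 37%, while compound 2 gives 24%. The step of a number 13 percentage points lower from compound 1 to compound 2 (beyond the scatter) shows that swapping benzyl in place of isopropyl on an amide-type nitrogen loses some inhibition. For the measured compounds named here, compound 2 therefore stands lowest of the two numbers measured so far, and its only neighbour, compound 1, sits a number higher by an amount beyond the scatter.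

Compound 3 `COc1cc2c(cc1OC)C(CC(=O)N1CCCCC1)CC2` is the next step: piperidin-1-yl in place of benzylamino on a carbonyl carbon. The amide hydrogen disappears along with the benzylamino group, and a piperidin-1-yl ring takes its place on the carbonyl carbon. Going by the values given here, only one measured step bears on this, the step from compound 1 to compound 2, which was modest and shows that the group on the amide-type nitrogen matters. Among the compounds with values here, no measured compound lacks the amide hydrogen, so nothing shows what its loss does. The step from compound 2 to compound 3 is therefore expected to be small, a number 4 percentage points higher from compound 2 to compound 3 (within the scatter), and it may well lie within the scatter. Compound 3 is estimated to give 28% in this assay, within the range 10% to 45%.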

Compound 3, a percentage reported as inhibition, in the whole organism at one dose (the size of the read-out at that dose, not a potency): 22%
For compound 3 the middle estimate is 6 percentage points above the measured one; the measured number falls inside the stated range.
By their numbers in this assay, from the lowest: compounds 3 and 2 (each within the scatter of the next); then compound 1.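

In this assay, replacing benzylamino with piperidin-1-yl on the carbonyl carbon removes the amide hydrogen and exchanges an aromatic ring of carbon for a non-aromatic ring with one hetero atom, yet the result is a number 2 percentage points lower from compound 2 to compound 3 (within the scatter), so this change leaves the two compounds indistinguishable. The second comparison, a number 15 percentage points lower from compound 1 to compound 3 (beyond the scatter), matches what benzyl did in place of isopropyl: compound 2 keeps the amide hydrogen and compound 3 lacks it, but both give less inhibition than compound 1, so keeping that hydrogen alone does not preserve the higher number. Nothing measured here explains why these groups give the values they do.

Both lower compounds carry a six-membered ring on the amide nitrogen side, so the ring and the loss of the hydrogen cannot yet be separated, and the effects of the two changes could even offset each other in compound 3. Going by these compounds, a dimethylamino group on the carbonyl carbon would lack the amide hydrogen without adding a ring, while a cyclohexylamino group would keep that hydrogen alongside a non-aromatic ring, and what either would give remains open.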